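Swapping one purine-like headgroup for another in a cytotoxicity test

A few compounds are considered here, and "the series" means these few. Any claim that something is new, unique, unknown or untested is made for them only; others in the source may bear on it.

Measured so far:
compound 1 `Cn1cnc2c(ncn2[C@@H]2O[C@H](CO[Si](C)(C)C(C)(C)C)[C@@]3(OS(=O)(=O)C=C3N)[C@H]2O[Si](C)(C)C(C)(C)C)c1=O`: > 150000 nM
compound 2 `CC(C)(C)[Si](C)(C)OC[C@H]1O[C@@H](n2cnc3cncnc32)[C@H](O[Si](C)(C)C(C)(C)C)[C@]12OS(=O)(=O)C=C2N`: 13000 nM
compound 3 `CNc1ncnc2c1ncn2[C@@H]1O[C@H](CO[Si](C)(C)C(C)(C)C)[C@@]2(OS(=O)(=O)C=C2N)[C@H]1O[Si](C)(C)C(C)(C)C`: 14000 nM

In a functional assay on MT4 cells (Homo sapiens) for cytotoxicity (on this read-out higher numbers stand for lower toxicity in this test and lower numbers for higher toxicity in this test), compound 1 gives only a limit, > 150000 nM. Compound 3 gives 14000 nM, the highest of the two plain numbers, with compound 2 at a 1.1-fold higher number from compound 2 to compound 3 (0.03 log units; within the scatter). Compound 4 `Cn1cnc2ncn([C@@H]3O[C@H](CO[Si](C)(C)C(C)(C)C)[C@@]4(OS(=O)(=O)C=C4N)[C@H]3O[Si](C)(C)C(C)(C)C)c2c1=O` differs from compound 3 by a group of 11 heavy atoms (6 carbon, 4 nitrogen, 1 oxygen; one five-membered aromatic ring with 2 hetero atoms, one six-membered aromatic ring with 2 hetero atoms) in place of a group of 11 heavy atoms (6 carbon, 5 nitrogen; one five-membered aromatic ring with 2 hetero atoms, one six-membered aromatic ring with 2 hetero atoms), on a saturated ring carbon. The entering group has the same make-up as the group of compound 1, arranged differently. The relevant measured step is the reverse exchange, an at least 10-fold lower number from compound 1 to compound 3 (1.02 log units; beyond the scatter), echoed by an at least 11-fold lower number from compound 1 to compound 2 (1.06 log units; beyond the scatter); both rest on (the limit of > 150000 nM in this assay, at which 1 of the 3 values shown sits). A large rise toward the limit is therefore expected in this assay, as a 4.3-fold higher number from compound 3 to compound 4 (0.63 log units; beyond the scatter). Compound 4 is estimated at 60000 nM, between 14000 nM and 150000 nM.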

Compound 4, half-maximal cytotoxic concentration: 156000 nM
Beside the measured number, compound 4's estimate is 2.6-fold (0.41 log units) below it; measured number outside the range, above it.
By their numbers in this assay, from the lowest: compounds 2 and 3 (each within the scatter of the next); then compound 4.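

At this position, on a saturated ring carbon, the oxygen-bearing group of compound 4 gives a plain number, so the size of the change can now be read: an 11-fold higher number from compound 3 to compound 4 (1.05 log units; beyond the scatter) and a 12-fold higher number from compound 2 to compound 4 (1.08 log units; beyond the scatter). Both steps point to much lower toxicity in this test than with the two groups lacking oxygen. The step between compound 1 and compound 4 cannot be read because compound 1 gives only a limit: the limit of > 150000 nM in this assay, at which 1 of the 4 values shown sits.

As far as these compounds go, whether a group with chlorine in place of that oxygen would keep the higher number stays open. The compounds shown also do not explain why the group's oxygen matters.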